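Hydroxy for methyl on the pendant ring of compound 1

This account rests on a few compounds, and the source may have more. Where it says the series, first, only, none or still open, it means among the compounds named here.

Among the compounds with values here, compound 1 `Cc1ccc(-c2ccccc2OC(C)C2=NCCN2)cc1` gives 0.46 in a functional assay on CHO cells for agonist activity at Alpha-2C adrenergic receptor (Homo sapiens) (on this read-out higher numbers stand for larger maximal responses and lower numbers for smaller maximal responses), the lower of the two numbers so far; compound 2 `CC(Oc1ccccc1-c1cccs1)C1=NCCN1` gives 0.8 there, and the change a number 0.34 higher from compound 1 to compound 2 (beyond the scatter) is the only measured step in the set. Compound 3 `CC(Oc1ccccc1-c1ccc(O)cc1)C1=NCCN1` differs from compound 1 by hydroxy in place of methyl on an aromatic carbon. Within the data shown here, no measured step matches this change: the one known step swaps the whole pendant ring rather than a group on it, so it says little about compound 3. A step of modest size in either direction, or none beyond the scatter, is expected as a number 0.090 higher from compound 1 to compound 3 (within the scatter). For compound 3 the value is estimated at 0.55, within 0.3 to 0.8.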

Compound 3, intrinsic activity: the largest response reached, as a fraction of the reference agonist's: < 0.3
Compound 3 was reported as a limit; the forecaster's own chance of this, stated with the estimate: 0%; at least 0.25 between middle value and limit.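

In this assay compound 3 gives < 0.3 as a limit of the assay and not a number. Hydroxy in place of methyl, para to a large group, gives a number at least 0.16 lower from compound 1 to compound 3 (beyond the scatter) and shows that this single position can lower the maximal response. Set against thiophen-2-yl, 4-hydroxyphenyl gives a number at least 0.50 lower from compound 2 to compound 3 (beyond the scatter) and the group on this aromatic carbon now moves the response both ways from compound 1, upward with compound 2 and downward with compound 3.

From the compounds shown here alone, the true size of both new steps stays open behind the limit. Going by these compounds, whether an amine or a methoxy group at the same place would also lower the response remains unknown.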